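Methylation of an exocyclic nitrogen in a sulfonamide series

The source may hold more compounds than are shown below. What is called first, only, known or untested is meant among the compounds shown, and "the series" means these compounds.

Compound 1 `COc1nn(CC(N)=O)c2ncnc(NS(=O)(=O)c3cccc(Cl)c3Cl)c12` gives 501 nM in a functional assay on cells for antagonist activity at C-C chemokine receptor type 4 (Homo sapiens), read by GTPgammaS binding; a lower number here means a stronger inhibitor, a higher number a weaker inhibitor. Compound 2 `CNC(=O)Cn1nc(OC)c2c(NS(=O)(=O)c3cccc(Cl)c3Cl)ncnc21` gives 631 nM in this assay; the change is methyl in place of hydrogen on an amide-type nitrogen and the step is a 1.3-fold higher number from compound 1 to compound 2 (0.10 log units; within the scatter). Compound 3 `COc1nn(C)c2nc(N)nc(NS(=O)(=O)c3cccc(Cl)c3Cl)c12` gives 316 nM in this assay; the difference between the cores of compound 3 and compound 1 is not broken down here. Compound 4 `CNc1nc(NS(=O)(=O)c2cccc(Cl)c2Cl)c2c(OC)nn(C)c2n1` is not yet measured in this assay. Its change from compound 3 is methyl in place of hydrogen on a nitrogen on an aromatic ring. This is the same kind of change as from compound 1 to compound 2, but not the same: there the methyl entered on an amide-type nitrogen whose other neighbour is a carbonyl carbon, here on a nitrogen on an aromatic ring whose other neighbour is aromatic carbon. Resting on the step of a 1.3-fold higher number from compound 1 to compound 2 (0.10 log units; within the scatter), a similarly small step a 1.3-fold higher number from compound 3 to compound 4 (0.10 log units; within the scatter) is expected. Compound 4 is estimated at 400 nM in this assay, between 180 nM and 900 nM.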

Compound 4, half-maximal inhibitory concentration in the C-C chemokine receptor type 4 assay: 79.4 nM
Compound 4: the middle estimate sits 5.0-fold (0.70 log units) above what was measured, and the stated range ends above it.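

In the C-C chemokine receptor type 4 assay the methyl gives a 4.0-fold lower number from compound 3 to compound 4 (0.60 log units; beyond the scatter) and does not match the earlier step, so this change does not carry over from one core to another as a step of one size: the same change on two cores in the C-C chemokine receptor type 4 assay, a 1.3-fold higher number (0.10 log units; within the scatter) from compound 1 to compound 2 and a 4.0-fold lower number (0.60 log units; beyond the scatter) from compound 3 to compound 4, 5.0-fold (0.70 log units) apart, beyond the scatter of two such steps. The comparison rests on one pair per core, and the methyl enters on an amide-type nitrogen in one pair and on a nitrogen on an aromatic ring in the other, so the effect of the core cannot be separated from that of the nitrogen. It gives no rule for further cores and no reason for the gap.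

Open, going by these compounds, is how an ethyl group, a longer chain or dimethylamino in place of methylamino would read on the core of compound 4. On these data alone, in a physicochemical assay for solubility, read by chemiluminescence, measured as kinetic solubility (on this read-out higher numbers stand for higher solubility and lower numbers for lower solubility), compound 3 gives >= 649000 nM, a limit of the assay; the exact size of any step from it stays open. In the physicochemical assay compound 4 gives 376000 nM.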